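A few compounds are considered here, and "the series" means these few. Any claim that something is new, unique, unknown or untested is made for them only; others in the source may bear on it.

Compound 1 `CC(=O)Nc1ccc(-n2nncc2CN2C(=O)C3(C(C#N)=C(N)Oc4c(N)cc5nc6ccccc6nc5c43)c3ccccc32)cc1` is one of two measured members of this series. In an ADME assay on L02 cells (Homo sapiens) for antiproliferative activity, read by MTT assay, with a stated time of 48 h (a higher number here means a weaker inhibitor, a lower number a stronger inhibitor), compound 1 gives only a limit of the assay, > 50000 nM. Compound 2 `Cc1ccc(-n2nncc2CN2C(=O)C3(C(C#N)=C(N)Oc4c(N)cc5nc6ccccc6nc5c43)c3ccccc32)cc1Cl` carries a 3-chloro-4-methylphenyl in place of the 4-acetamidophenyl on an aromatic nitrogen. In this assay compound 2 likewise gives only a limit, > 50000 nM. The step that the two limits leave unreadable from compound 1 to compound 2 therefore cannot be read. Both values sit at the same limit (the limit of > 50000 nM in this assay, at which 2 of the 2 values shown sit), so compound 2 stands where compound 1 stands, without a number of its own. Compound 3 `N#CC1=C(N)Oc2c(N)cc3nc4ccccc4nc3c2C12C(=O)N(Cc1cnnn1-c1ccc(F)c(Cl)c1)c1ccccc12` differs from compound 2 by fluoro in place of methyl on an aromatic carbon. Among the compounds with values here, the one measured step carries no readable size, so nothing points to a move beyond the scatter in this assay. The step is expected to be a step that the limit leaves unreadable from compound 2 to compound 3. Compound 3 is estimated at 60000 nM, between 25000 nM and 150000 nM, most likely reported again as a limit.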

Compound 3, half-maximal inhibitory concentration: > 50000 nM
Compound 3 was reported as a limit (the forecaster's own chance of this, stated with the estimate: 85%); the middle value lies beyond the limit too.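

Compound 3 also gives only a limit, so its steps from compound 1 and compound 2 cannot be read, and all three compounds stand at the same limit: the limit of > 50000 nM in this assay, at which 3 of the 3 values shown sit.

The compounds shown leave open how strongly any of them inhibits these cells, and whether changing the aryl group alters that.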